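Phenyl to Thiophen-3-yl at the Low End

This account rests on a few compounds, and the source may have more. Where it says the series, first, only, none or still open, it means among the compounds named here.

Of the compounds shown here, two sharing one core have been measured in an assay on isolated protein for inhibition of DNA topoisomerase 1 (Homo sapiens), with a stated time of 30 min, tested at 100 uM; on this read-out higher numbers stand for a stronger effect at the one concentration tested and lower numbers for a weaker effect. Compound 1 `Oc1cccc(-c2cc(-c3ccsc3)nc(-c3cccc(Cl)c3)c2)c1` gives 26.2%. Compound 2 `Oc1cccc(-c2cc(-c3ccccc3)nc(-c3ccccc3Cl)c2)c1` gives 3.2%, the lowest of the two numbers; its nearest neighbour is compound 1, higher by a gap beyond the usual scatter. Compound 1 and compound 2 differ in two places, so their values show only where each whole compound stands. Compound 3 `Oc1cccc(-c2cc(-c3ccsc3)nc(-c3ccccc3Cl)c2)c1` has not yet been measured. It differs from compound 2 in one place: thiophen-3-yl in place of phenyl on an aromatic carbon. Going by the values given here, no step of this kind between measured compounds is known. Since compound 1, which also carries a thiophen-3-yl group, gives 26.2%, an upward step is expected, though it may not exceed the scatter. Compound 3 is expected to give 12%, within a range from 0% to 30%. This estimate means an expected step of a number 8.8 percentage points higher from compound 2 to compound 3 (within the scatter).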

Compound 3, a percentage reported as inhibition, at one concentration (the size of the read-out at that concentration, not a potency): 0%
Estimate against measurement, compound 3: 12 percentage points above; the range from low to high includes it.
By their numbers in this assay, from the lowest: compounds 3 and 2 (each within the scatter of the next); then compound 1.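

In this assay, thiophen-3-yl in place of phenyl, on the aromatic carbon next to the ring nitrogen, gives a number 3.2 percentage points lower from compound 2 to compound 3 (within the scatter), so with a 2-chlorophenyl group present this change does not separate the two compounds. With thiophen-3-yl held constant, 2-chlorophenyl in place of 3-chlorophenyl gives a number 26.2 percentage points lower from compound 1 to compound 3 (beyond the scatter), which ties the higher number of compound 1 to its 3-chlorophenyl group rather than to thiophen-3-yl alone. Nothing at hand explains why either change has the outcome it does.

Whether thiophen-3-yl and phenyl would also read alike alongside a 3-chlorophenyl group remains open, since the compounds shown pair them only with 2-chlorophenyl. Also open, as far as these compounds go, is how a methoxy group or an amine in place of the chlorine would read in this assay.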